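The compounds below may be only part of what the source reports. "The series", "measured", "known", "first", "only" and "open" are said of these compounds alone.

Measured so far in an assay on CHO cells for displacement of a labelled ligand from adenosine receptor A1 (Homo sapiens), read by scintillation counting, with a stated time of 3 h; on this read-out higher numbers stand for weaker inhibition and lower numbers for stronger inhibition:
compound 1 `Cn1c(-c2ccccc2)nc2c(NC3CCCCC3)ncnc21`, 5.7 nM;
compound 2 `CCCn1c(-c2ccccc2)nc2c(NC3CCC3)ncnc21`, 15 nM;
compound 3 `CCCn1c(-c2ccccc2)nc2c(NC3CCOC3)ncnc21`, 25 nM.

Compound 2 stands second highest of the three numbers, with compound 3 nearest and compound 1 furthest. Compound 4 `Cn1c(-c2ccccc2)nc2c(NC3CCC3)ncnc21` differs from compound 2 by hydrogen in place of ethyl on a saturated chain carbon bound to an aromatic nitrogen. Among the measured compounds shown here, no measured step isolates this change: the only one-place step, a 1.7-fold higher number from compound 2 to compound 3 (0.22 log units; within the scatter), alters the other substituent and lies within the scatter, so it does not bear on it. Compound 1 carries methyl at the same place but also a different ring, so its values with compound 2 cannot separate the two changes. The step from compound 2 to compound 4 is therefore expected to be small, a 1.3-fold lower number from compound 2 to compound 4 (0.10 log units; within the scatter). Compound 4 is estimated at 12 nM, in the range 4 nM to 35 nM.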

Compound 4, inhibition constant: 3.2 nM
For compound 4 the middle estimate is 3.8-fold (0.57 log units) above the measured one, outside the stated range (below it).
By their numbers in this assay, from the lowest: compounds 4 and 1 (each within the scatter of the next); then compounds 2 and 3 (each within the scatter of the next).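

In this assay, among the compounds shown here, going from propyl to methyl on the aromatic nitrogen gives a 4.7-fold lower number from compound 2 to compound 4 (0.67 log units; beyond the scatter) as the first measured step at this place, showing that the chain there can matter. With methyl in place, cyclobutyl for cyclohexyl gives a 1.8-fold lower number from compound 1 to compound 4 (0.25 log units; within the scatter) and so shows no clear effect of that ring change. Nothing measured here explains the chain step.

Still open, on these data alone, is how an ethyl or butyl chain on that nitrogen would compare, so no trend with chain length can be drawn. It is also unknown whether oxolan-3-yl would behave the same way alongside methyl.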